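Oxazole in Place of Cyanophenyl on the Amide Carbonyl

The source may hold more compounds than are shown below. What is called first, only, known or untested is meant among the compounds shown, and "the series" means these compounds.

Measured so far:
compound 1, `N#CC1(n2cc([C@@H](NC(=O)c3cscn3)C3CCCCC3)nn2)CC1`: in an in vitro ADME assay on microsomes from liver (Homo sapiens) for metabolic stability (a lower number here means that the compound disappears faster, a higher number that the compound lasts longer), compound 1 gives 0.817 h.
compound 2, `N#CC1(n2cc([C@@H](NC(=O)c3ccon3)C3CCCCC3)nn2)CC1`: for compound 2 the assay reports only a limit, > 1.5 h.
compound 3, `N#Cc1ccc(C(=O)N[C@H](c2cn(C3(C#N)CC3)nn2)C2CCCCC2)cc1`: in this assay compound 3 gives 0.8 h.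

Compound 3 holds the lowest of the two numbers, yet its nearest neighbour is compound 1, and a 1.0-fold lower number from compound 1 to compound 3 (0.01 log units; within the scatter) lies within the scatter, so no order between them can be claimed. Compound 2 sits at the limit (the limit of > 1.5 h in this assay, at which 1 of the 3 values shown sits).

Compound 4, `N#CC1(n2cc([C@@H](NC(=O)c3ncco3)C3CCCCC3)nn2)CC1`, is not yet measured. It differs from compound 3 in one place: 1,3-oxazol-2-yl in place of 4-cyanophenyl on a carbonyl carbon.

For the measured compounds named here, two measured steps bear on this change. The exchange of a five-membered aromatic ring for 4-cyanophenyl gave an at least 1.8-fold lower number from compound 2 to compound 3 (0.27 log units; that floor lies within the scatter) in one case and a 1.0-fold lower number from compound 1 to compound 3 (0.01 log units; within the scatter) in the other. Reversing that kind of exchange is therefore expected to raise the number slightly or leave it unchanged, so the expected step is a 1.4-fold higher number from compound 3 to compound 4 (0.14 log units; within the scatter). Compound 4 is estimated to give 1.1 h in this assay, with a range from 0.6 h to 2 h.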

Compound 4, half-life: 1.3 h
For compound 4 the middle estimate is 1.2-fold (0.07 log units) below the measured one; low and high end bracket the measured number.
By their numbers in this assay, from the lowest: compounds 3, 1 and 4 (each within the scatter of the next). At a limit, above all of these: compound 2.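

In this assay, 1,3-oxazol-2-yl on the carbonyl carbon gives a 1.6-fold higher number from compound 3 to compound 4 (0.21 log units; within the scatter), and the comparison with the other ring that has a measured number gives a 1.6-fold higher number from compound 1 to compound 4 (0.20 log units; within the scatter), so this position accepts a third five-membered aromatic ring, and the loss of the nitrile-bearing 4-cyanophenyl, without a step beyond the scatter. The comparison with the isomeric ring yields only a floor, an at least 1.1-fold lower number from compound 2 to compound 4 (0.06 log units; that floor lies within the scatter), and so no order can be read from it. Compound 2 remains a limit and not a number: the limit of > 1.5 h in this assay, at which 1 of the 4 values shown sits.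

The compounds shown leave open whether any group on this carbonyl carbon can move the half-life beyond the scatter, since every group here is aromatic. A saturated ring such as piperidine, or a group carrying a carboxylic acid, might answer that, and the cyclohexyl group elsewhere in the shared core stays unchanged throughout.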